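Compound 1 to Compound 3 in a Cytotoxicity Screen

The source may hold more compounds than are shown below. What is called first, only, known or untested is meant among the compounds shown, and "the series" means these compounds.

Compound 1, `O=C(CCCCCCCc1cn(-c2ccccc2-c2ccccc2)nn1)Nc1ccncc1`, stands lowest of the two compounds tested in a functional assay on SH-SY5Y cells (Homo sapiens) for cytotoxicity, read by MTT assay, with a stated time of 48 h, tested at 10 uM; on this read-out higher numbers stand for a weaker effect at the one concentration tested and lower numbers for a stronger effect: there compound 1 gives 32%, while compound 2, `O=C(CCCCCCCCc1cn(-c2cnc3ccccc3c2)nn1)Nc1ccncc1`, gives 53%, a gap beyond the usual scatter. Compound 3, `O=C(CCCCCc1cn(-c2ccccc2-c2ccccc2)nn1)NCc1cccnc1`, is not yet measured. It differs from compound 1 by a group of 10 heavy atoms (7 carbon, 2 nitrogen, 1 oxygen; one six-membered aromatic ring with 1 hetero atom) in place of a group of 11 heavy atoms (8 carbon, 2 nitrogen, 1 oxygen; one six-membered aromatic ring with 1 hetero atom), on a saturated chain carbon, five bonds along the chain from an aromatic carbon. Going by the values given here, no measured pair shows what this change does, so only a small step is expected, probably upward but not beyond the scatter. For compound 3 a value of 40% is estimated, between 20% and 65%. The expected step is a number 8 percentage points higher from compound 1 to compound 3 (within the scatter), within the scatter.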

Compound 3, a percentage reported as activity, at one concentration (the size of the read-out at that concentration, not a potency): 12.5%
Compound 3: middle estimate off by 27.5 percentage points, on the high side, and the stated range ends above it.
By their numbers in this assay, from the lowest: compound 3; then compound 1; then compound 2.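

At this saturated chain carbon, five bonds along the chain from an aromatic carbon, ((pyridin-3-yl)methyl)carbamoyl in place of the earlier group of 11 heavy atoms gives, in this assay, a number 19.5 percentage points lower from compound 1 to compound 3 (beyond the scatter). This first readable pair shows that the read-out responds to a change at this position, here towards a stronger effect at the one concentration tested. Nothing at hand accounts for this step. From the compounds shown here alone, a single pair carries this finding, so its generality stays open. Also open, going by these compounds, is how a carboxylic acid or a primary amine at this position would read.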